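This account rests on a few compounds, and the source may have more. Where it says the series, first, only, none or still open, it means among the compounds named here.

Working notes on the series. Within the data shown here, in a functional assay on HeLa cells (Homo sapiens) for inhibition, read by MTT assay, with a stated time of 48 h (a higher number here means a weaker inhibitor, a lower number a stronger inhibitor), compound 1 `O=C(CC(c1ccc([N+](=O)[O-])cc1)C(C(=O)Nc1ccccn1)C(=O)Nc1ccccn1)c1ccccc1` gives 30000 nM and compound 2 `O=C(CC(c1ccc(Cl)cc1Cl)C(C(=O)Nc1ccccn1)C(=O)Nc1ccccn1)c1ccccc1` gives 13500 nM, so compound 2 holds the lower of the two numbers so far. Compound 3 `O=C(CC(c1c(Cl)cccc1Cl)C(C(=O)Nc1ccccn1)C(=O)Nc1ccccn1)c1ccccc1` keeps the shared core and alters only the dichlorophenyl group: 2,6-dichlorophenyl in place of 2,4-dichlorophenyl on a saturated chain carbon bound to two saturated chain carbons. Among the measured compounds shown here, the one measured step at this place is a 2.2-fold lower number from compound 1 to compound 2 (0.35 log units; beyond the scatter), a modest change that exchanged 4-nitrophenyl for 2,4-dichlorophenyl. For the measured compounds named here, that step does not compare two dichlorophenyl groups, and no measured pair does, so it gives no direction for this change. In this assay, no step beyond the scatter is therefore expected. The expected step is a 1.1-fold higher number from compound 2 to compound 3 (0.05 log units; within the scatter). For compound 3 the estimated value is 15000 nM, with an expected range of 6000 nM to 35000 nM.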

Compound 3, half-maximal inhibitory concentration: "not active" (no number reported)
Compound 3: no number reported; no gap can be computed for the estimate.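

Among these compounds, compound 3 is reported as "not active" in this assay without a number, so no step from compound 2 to compound 3 can be read. The compounds shown leave open how far 2,6-dichlorophenyl and 2,4-dichlorophenyl differ in this read-out. Nothing available bears on this result.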